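The source may report more compounds than this note shows. Statements on the series, on what has been measured and on what is new or still open speak of the compounds shown alone.

Among the measured compounds shown here, compound 3 `NC(=O)OC(CCN1CCN(c2ccccc2)CC1)c1ccc(Cl)cc1` gives 2.1 mg/kg in a functional assay on the whole organism for inhibition, with Mus musculus as the target, in the writhing test, with a stated time of 1 h (on this read-out lower numbers stand for an effect already at smaller amounts and higher numbers for an effect only at larger amounts of compound), the lowest of the three numbers measured so far. Compound 1 `COc1ccc(N2CCN(CCC(OC(N)=O)c3ccc(F)cc3)CC2)cc1` gives 12.4 mg/kg and compound 2 `NC(=O)OC(CCN1CCN(c2cccc(Cl)c2)CC1)c1ccccc1` gives 17.5 mg/kg, both of them beyond the scatter from compound 3. Compound 4 `NC(=O)OC(CCN1CCN(c2ccccc2)CC1)c1ccc(F)cc1` is not yet measured; its change from compound 3 is fluoro in place of chloro on an aromatic carbon. For the measured compounds named here, no measured pair shows this exchange alone; compound 1 also carries fluoro but differs in the piperazine aryl as well, so its number gives no clean reading of the exchange. A small move toward higher numbers is expected, possibly no larger than the scatter. The expected step of a 1.9-fold higher number from compound 3 to compound 4 (0.28 log units; within the scatter) is modest. Compound 4 is estimated at 4 mg/kg, within 1.5 mg/kg to 11 mg/kg.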

Compound 4, dose for half-maximal effect: 2.79 mg/kg
Compound 4: middle estimate off by 1.4-fold (0.16 log units), on the high side, and the stated range covers the measured number.
By their numbers in this assay, from the lowest: compounds 3 and 4 (each within the scatter of the next); then compounds 1 and 2 (each within the scatter of the next).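

The exchange of 4-chlorophenyl to 4-fluorophenyl now has a direct reading (a 1.3-fold higher number from compound 3 to compound 4 (0.12 log units; within the scatter)): at this position, the two halogens cannot be told apart in this assay. With the 4-fluorophenyl held fixed, hydrogen in place of methoxy on an aromatic carbon gives a step beyond the scatter (a 4.4-fold lower number from compound 1 to compound 4 (0.65 log units; beyond the scatter)). No supporting data bear on the reason for either step.

Still open, on these data alone, is what a trifluoromethyl, a nitrile or an unsubstituted phenyl would give at this position. The effect of chloro in compound 2 also stays open, with no one-place partner among these compounds.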